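Cytotoxicity of three esters and one untested furan ester

The source may hold more compounds than are shown below. What is called first, only, known or untested is meant among the compounds shown, and "the series" means these compounds.

In a functional assay on Vero cells (Chlorocebus sabaeus) for cytotoxicity (on this read-out lower numbers stand for higher toxicity in this test and higher numbers for lower toxicity in this test), the measured compounds stand as follows:

compound 1, `CCCCCCCCOC(=O)C(O)Cn1cnc2c(N)ncnc21`: 200 ug/mL
compound 2, `CCCCOC(=O)C(O)Cn1cnc2c(N)ncnc21`: 200 ug/mL
compound 3, `CC(C)OC(=O)C(O)Cn1cnc2c(N)ncnc21`: > 400 ug/mL, a limit of the assay

Compound 1 sits level with compound 2, as no change at the digits printed from compound 1 to compound 2 (within the scatter) shows. Compound 3 reaches only (the limit of > 400 ug/mL in this assay, at which 1 of the 3 values shown sits), so an at least 2.0-fold higher number from compound 1 to compound 3 (0.30 log units; that floor lies within the scatter) and an at least 2.0-fold higher number from compound 2 to compound 3 (0.30 log units; that floor lies within the scatter) carry a floor that lies within the scatter. Compound 4, `Nc1ncnc2c1ncn2CC(O)C(=O)OCc1ccco1`, differs from compound 1 by furan-2-yl in place of heptyl on a saturated chain carbon bound to an oxygen next to a carbonyl group. All three measured steps change the group on the oxygen next to the carbonyl group, and none moved the read-out beyond the scatter. Compound 4 is therefore expected to show no change at the digits printed from compound 1 to compound 4 (within the scatter), that is, a number of about 200 ug/mL, with a range from 100 ug/mL to 400 ug/mL.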

Compound 4, minimum cytotoxic concentration: 40 ug/mL
Beside the measured number, compound 4's estimate is 5.0-fold (0.70 log units) above it; measured number outside the range, below it.
By their numbers in this assay, from the lowest: compound 4; then compounds 1 and 2 (each within the scatter of the next). At a limit, above all of these: compound 3.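

In this assay the read-out shows a 5.0-fold lower number from compound 1 to compound 4 (0.70 log units; beyond the scatter) and a 5.0-fold lower number from compound 2 to compound 4 (0.70 log units; beyond the scatter) with furan-2-yl entering on a saturated chain carbon bound to an oxygen next to a carbonyl group, so a change at this position now goes beyond the scatter. The step of an at least 10-fold lower number from compound 3 to compound 4 (1.00 log units; beyond the scatter) is a floor only: the limit of > 400 ug/mL in this assay, at which 1 of the 4 values shown sits.

The compounds shown leave open whether the aromatic ring or its oxygen goes with this lower number. Esters carrying benzyl, thiophen-2-ylmethyl or tetrahydrofuran-2-ylmethyl would separate the two.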